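Benzyl extension of the piperazine amide in the series

The compounds below may be only part of what the source reports. "The series", "measured", "known", "first", "only" and "open" are said of these compounds alone.

Three compounds in this set share one core and differ in the group on the chain carbon bound to the carbonyl. In a functional assay on MCF7 cells (Homo sapiens) for cytotoxicity, read by MTT assay, with a stated time of 24 h, tested at 80 ug/mL (a lower number here means a weaker effect, a higher number a stronger effect of the compound at the concentration tested), compound 1 `Cn1c(-c2ccc(NC(=O)CSc3nc4cc(Cl)ccc4o3)cc2)nc(-c2ccccc2)c1-c1ccccc1` gives 69.1% and compound 2 `Cc1ccc2oc(SCC(=O)Nc3ccc(-c4nc(-c5ccccc5)c(-c5ccccc5)n4C)cc3)nc2c1` gives 65.1%; the two lie within the scatter, a number 4 percentage points lower from compound 1 to compound 2 (within the scatter). Compound 3 `CN1CCN(CC(=O)Nc2ccc(-c3nc(-c4ccccc4)c(-c4ccccc4)n3C)cc2)CC1` gives 50.3%, the lowest of the three, with a number 18.8 percentage points lower from compound 1 to compound 3 (beyond the scatter) and a number 14.8 percentage points lower from compound 2 to compound 3 (beyond the scatter).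

Compound 4 `Cc1ccc(CN2CCN(CC(=O)Nc3ccc(-c4nc(-c5ccccc5)c(-c5ccccc5)n4C)cc3)CC2)cc1` differs from compound 3 by 4-methylphenyl in place of hydrogen on a saturated chain carbon bound to an amine nitrogen in a ring. Among the measured compounds shown here, no measured step alters this position, so the two steps into compound 3 give only context: removing the aromatic sulfanyl group cost a modest amount, and restoring an aromatic ring elsewhere may recover part of it. A modest rise is therefore expected, a number 7.7 percentage points higher from compound 3 to compound 4 (within the scatter), and compound 4 is estimated at 58% within 45% to 71%.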

Compound 4, a percentage reported as activity, at one concentration (the size of the read-out at that concentration, not a potency): 49.3%
Estimate against measurement, compound 4: 8.7 percentage points above, within the range that was stated.
By their numbers in this assay, from the lowest: compounds 4 and 3 (each within the scatter of the next); then compounds 2 and 1 (each within the scatter of the next).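

In this assay, the change from methyl to 4-methylbenzyl on the piperazine nitrogen gives a number 1 percentage points lower from compound 3 to compound 4 (within the scatter). At this position, the added 4-methylphenyl ring, with its 7 heavy atoms, therefore produces no readable change in the read-out at the single concentration tested. No available evidence explains this result.

Open, on these data alone, is whether a carboxylic acid or an amine on the added ring, or a longer chain in place of the benzyl link, would move the read-out beyond the scatter.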